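From a Phenylpropyl Urea to a Sec-Butyl Urea

This account rests on a few compounds, and the source may have more. Where it says the series, first, only, none or still open, it means among the compounds named here.

In an assay on HEK293 cells for inhibition of Voltage-dependent T-type calcium channel subunit alpha-1H (Homo sapiens), read by patch clamp, using a membrane potential dye (on this read-out higher numbers stand for weaker inhibition and lower numbers for stronger inhibition), compound 2 (`CC[C@H](NC(=O)N1CCC2(CC1)C(=O)N(c1cccc(F)c1)C2c1ccc(Cl)cc1)c1ccccc1`) gives 224 nM. Its only measured companion, compound 1 (`CC[C@H](C)[C@H](NC(=O)N1CCC2(CC1)C(=O)N(c1cccc(F)c1)C2c1ccc(Cl)cc1)C(=O)NC`), gives 182 nM, and the step of a 1.2-fold higher number from compound 1 to compound 2 (0.09 log units; within the scatter) lies within the scatter, so the two numbers stand together and compound 2 is not separated from compound 1 by this assay. Compound 3 (`CCC(C)NC(=O)N1CCC2(CC1)C(=O)N(c1cccc(F)c1)C2c1ccc(Cl)cc1`) is not yet measured; it differs from compound 2 by sec-butyl in place of 1-phenylpropyl on an amide-type nitrogen. Among the compounds with values here, the one step on record, from compound 1 to compound 2, bears only loosely on this question: it exchanged one substituent on the amide-type nitrogen for another of similar size and left the read-out unmoved, whereas here the six-membered aromatic ring departs and a short sec-butyl chain remains. A step of modest size toward weaker inhibition is therefore expected, a 2.0-fold higher number from compound 2 to compound 3 (0.30 log units; within the scatter). Compound 3 is estimated at 450 nM, with a range from 150 nM to 1300 nM.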

Compound 3, half-maximal inhibitory concentration: 1250 nM
Beside the measured number, compound 3's estimate is 2.8-fold (0.44 log units) below it, within the range that was stated.
By their numbers in this assay, from the lowest: compounds 1 and 2 (each within the scatter of the next); then compound 3.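

In this assay, the substituent on this amide-type nitrogen now proves able to move the read-out: the change to sec-butyl gives a 5.6-fold higher number from compound 2 to compound 3 (0.75 log units; beyond the scatter) and a 6.9-fold higher number from compound 1 to compound 3 (0.84 log units; beyond the scatter) toward weaker inhibition. The earlier pair had shown only that 1-phenylpropyl and 2-methyl-1-(methylcarbamoyl)butyl stand together within the scatter, whereas sec-butyl is the first group here to separate from both. The data shown offer no explanation for this loss of inhibition.

The compounds shown leave open whether the departing six-membered aromatic ring or the shortened chain carries the difference, a question that a benzyl group or a longer alkyl chain on the same nitrogen would address. Also open, going by these compounds, is how a substituent bearing an amine or a carboxylic acid would read at this position.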